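Acetyl to dimethylamino on the pendant phenyl ring

The source may hold more compounds than are shown below. What is called first, only, known or untested is meant among the compounds shown, and "the series" means these compounds.

Compound 1 `COc1cc(C)cc(-c2c(-c3ccnc(-c4ccc(C(C)=O)cc4)c3)cnn2CC#N)c1` gives 15% in a functional assay on SF-268 cells (Homo sapiens) for cytotoxicity, read by sulforhodamine B assay, with a stated time of 48 h, tested at 1 uM; a higher number here means a weaker effect of the compound at the concentration tested, a lower number a stronger effect. Among the measured compounds shown here, this is the lowest of the three numbers measured so far, though both gaps lie within the scatter: compound 2 `Cc1cc(O)cc(-c2nn(CC#N)cc2-c2ccnc(-c3ccc(Oc4ccccc4)cc3)c2)c1` gives 22%, and compound 3 `Cc1cc(O)cc(-c2nn(CC#N)cc2-c2ccnc(-c3ccc(N(C)C)cc3)c2)c1` gives 17%. Compound 4 `COc1cc(C)cc(-c2c(-c3ccnc(-c4ccc(N(C)C)cc4)c3)cnn2CC#N)c1` differs from compound 1 in one place: dimethylamino in place of acetyl on an aromatic carbon. The change sits on an aromatic carbon of a six-membered aromatic ring of carbon only, para to a large group, so that 4-acetylphenyl becomes 4-(dimethylamino)phenyl. For the measured compounds named here, the only measured step introducing dimethylamino, a number 5 percentage points lower from compound 2 to compound 3 (within the scatter), stays within the scatter, but it exchanges phenoxy rather than acetyl, so no directly comparable step exists. The step of a number 1 percentage points higher from compound 1 to compound 4 (within the scatter) is therefore expected to remain within the scatter. Compound 4 is estimated at 16%, between 6% and 30%.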

Compound 4, a percentage reported as activity, at one concentration (the size of the read-out at that concentration, not a potency): 24%
Beside the measured number, compound 4's estimate is 8 percentage points below it; measured number inside the range.
By their numbers in this assay, from the lowest: compounds 1, 3, 2 and 4 (each within the scatter of the next).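

In this assay, 4-acetylphenyl to 4-(dimethylamino)phenyl gives a number 9 percentage points higher from compound 1 to compound 4 (within the scatter), so on the core of compound 1 this exchange does not separate the two groups. Dimethylamino now has a second measured step, this one from acetyl rather than phenoxy, and both steps stay within the scatter. No measurement bearing on the reason for this result is available.

From the compounds shown here alone, whether a carboxylic acid or a longer amine chain on this aromatic carbon would move the read-out beyond the scatter remains open. Going by these compounds, the read-out also describes only the size of the effect at the single tested concentration, and whether the effect would be stronger or weaker at other concentrations remains open.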